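The source may hold more compounds than are shown below. What is called first, only, known or untested is meant among the compounds shown, and "the series" means these compounds.

Measured compounds:
compound 1, `Cc1cccc(CSc2cc(Cl)c(C)cc2S(=O)(=O)/N=C(\N)n2nccc2-c2ccccc2)c1`, 47000 nM
compound 2, `Cc1cc(-c2ccccc2)n(/C(N)=N/S(=O)(=O)c2cc(C)c(Cl)cc2SCc2cccc3ccccc23)n1`, 170000 nM

In a functional assay on MCF7 cells (Homo sapiens) for cytotoxicity, read by MTT assay, with a stated time of 72 h (on this read-out lower numbers stand for stronger inhibition and higher numbers for weaker inhibition), compound 2 gives 170000 nM. Among the measured compounds shown here, that is the higher of the two numbers measured so far. Compound 1 gives 47000 nM, and the gap between the two lies beyond the usual scatter of repeated measurements. For the measured compounds named here, compound 1 and compound 2 differ in more than one place, so no single step between them can be read off.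

Compound 3, `Cc1ccc(CSc2cc(Cl)c(C)cc2S(=O)(=O)/N=C(\N)n2nc(C)cc2-c2ccccc2)cc1`, has not yet been measured in this assay. It differs from compound 2 in one place: 4-methylphenyl in place of naphthalen-1-yl on a saturated chain carbon bound to a sulfur. Compound 3 thus carries a 4-methylbenzyl group where compound 2 carries a (naphthalen-1-yl)methyl group, while the rest of the shared core is unchanged.

Going by the values given here, with only two measured compounds, the expected effect of this change can be framed only loosely. A move toward a lower number is expected, because in this assay compound 1 gives 47000 nM with a smaller group on the same chain carbon. The expected step is a 2.6-fold lower number from compound 2 to compound 3 (0.42 log units; beyond the scatter). Compound 3 is therefore estimated at 65000 nM, within a range from 25000 nM to 180000 nM.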

Compound 3, half-maximal inhibitory concentration: 89000 nM
Estimate against measurement, compound 3: 1.4-fold (0.14 log units) below; the measured number falls inside the stated range.
By their numbers in this assay, from the lowest: compounds 1, 3 and 2 (each within the scatter of the next, the first and the last beyond it).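

In this assay, among the compounds shown here, the exchange of naphthalen-1-yl for 4-methylphenyl on a saturated chain carbon bound to a sulfur gives the first one-place comparison at this position, and it reads a 1.9-fold lower number from compound 2 to compound 3 (0.28 log units; within the scatter). The group goes from two six-membered aromatic rings and 10 heavy atoms to one such ring and 7 heavy atoms, yet the read-out does not separate the two compounds, so this change has no effect that can be distinguished from the scatter. The compounds shown offer no measurement that accounts for this result.

On these data alone, it remains open whether any group at this position would move the number beyond the scatter of compound 3, for example a plain benzyl, a 4-aminobenzyl or a 4-carboxybenzyl group. As far as these compounds go, it is also open how a longer chain ending in a phenyl ring would read in place of the (4-methylbenzyl)sulfanyl group, since the two groups compared here both carry the same short link to the sulfur.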